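Cyano for fluoro on the aryl group of compound 1

The source may report more compounds than this note shows. Statements on the series, on what has been measured and on what is new or still open speak of the compounds shown alone.

Measured compounds:
compound 1, `COc1ccc(S(=O)(=O)n2ccc3cccc(-c4ccc(F)cc4)c32)cc1`: 170 nM
compound 2, `COc1ccc(S(=O)(=O)N2CCc3cccc(-c4cccs4)c32)cc1`: 165 nM

In a functional assay on MKN-45 cells (Homo sapiens) for inhibition, with a stated time of 72 h (a higher number here means a weaker inhibitor, a lower number a stronger inhibitor), compound 1 gives 170 nM, the highest of the two numbers shown. Compound 2 gives 165 nM in this assay, and the two values lie within the usual scatter of each other, so nothing separates them.

Compound 3, `COc1ccc(S(=O)(=O)n2ccc3cccc(-c4ccc(C#N)cc4)c32)cc1`, has not yet been measured in this assay. It differs from compound 1 in one place: cyano in place of fluoro on an aromatic carbon. Going by the values given here, no pair of measured compounds tracks this exchange, so the size of its effect is unknown from the numbers at hand. The account therefore rests on compound 1 alone.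

Compound 3 is expected to give about 150 nM in this assay, in a range from 50 nM to 450 nM. The estimated step of a 1.1-fold lower number from compound 1 to compound 3 (0.05 log units; within the scatter) is expected to stay within the scatter, in no clear direction.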

Compound 3, half-maximal inhibitory concentration: 143 nM
Compound 3: middle estimate off by 1.0-fold (0.02 log units), on the high side; measured number inside the range.
By their numbers in this assay, from the lowest: compounds 3, 2 and 1 (each within the scatter of the next).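

In this assay, cyano in place of fluoro on the aromatic carbon para to a large group gives a 1.2-fold lower number from compound 1 to compound 3 (0.08 log units; within the scatter), the first step read at this position. The exchange from 4-fluorophenyl to 4-cyanophenyl therefore adds a triple bond and a hydrogen-bond acceptor here without moving the number beyond the scatter, so the position accepts both groups on the core of compound 1. No measurement at hand offers an explanation for this outcome.

The compounds shown leave open whether an amine, a carboxylic acid or a longer chain at this position would produce a step beyond the scatter. They also leave open whether cyano would give a similar number on another carbon of the same aromatic ring.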